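The source may hold more compounds than are shown below. What is called first, only, known or untested is meant among the compounds shown, and "the series" means these compounds.

Working notes on the series, all read in an ADME assay on RAW264.7 cells (Mus musculus) for cytotoxicity, read by MTT assay; on this read-out lower numbers stand for stronger inhibition and higher numbers for weaker inhibition. Compound 1 (`COc1ccc(C(=O)/C=C/C=C/c2ccccc2)cc1`) is the only anchor, and it is a weak one. In this assay compound 1 gives > 100000 nM, which is a limit of the assay and not a number. Compound 2 (`O=C(/C=C/C=C/c1ccccc1)c1ccc(F)cc1`) adds nothing to the scale: in this assay compound 2 stands as "not determined" (no result reported). For the measured compounds named here, the series therefore holds no measured step, and compound 1 is placed from one side only.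

Compound 3 (`COc1ccc(C(=O)/C=C/C=C/c2ccc(N(C)C)cc2)cc1`) keeps the core of compound 1 and differs in one place: dimethylamino in place of hydrogen on an aromatic carbon. This is dimethylamino in place of hydrogen on an aromatic carbon, para to a large group. Going by the values given here, no measured step gives a size for this change, so the expectation is loose. A modest move toward stronger inhibition is expected, and a result that stays at the limit remains quite possible. The expected step is an at least 1.6-fold lower number from compound 1 to compound 3 (0.22 log units; that floor lies within the scatter). For compound 3 the estimated value is 60000 nM, with an expected range from 15000 nM to 150000 nM.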

Compound 3, half-maximal inhibitory concentration: > 100000 nM
Compound 3: a limit, no number (the forecaster's own chance of this, stated with the estimate: 50%); middle value at least 1.6-fold (0.22 log units) away from the limit.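

In this assay compound 3 gives > 100000 nM, which is a limit and not a number. No step can be read between compound 1 and compound 3, because both stand at the same limit: the limit of > 100000 nM in this assay, at which 2 of the 3 values shown sit.

The compounds shown leave open whether dimethylamino in place of hydrogen on an aromatic carbon changes the read-out at all.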